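Adding a Chloro Group to Compound 3

This account rests on a few compounds, and the source may have more. Where it says the series, first, only, none or still open, it means among the compounds named here.

Of the compounds shown here, three have been measured in an assay on CHO cells for displacement of a labelled ligand from adenosine receptor A1 (Homo sapiens), read by scintillation counting, with a stated time of 120 min, tested at 1 uM; a higher number here means more inhibition at the concentration tested (going by the name of the read-out), a lower number less inhibition. Compound 1 `Cc1nc2sc(-n3cccc3)nc2c(=O)[nH]1` gives 1%, compound 2 `Cc1ccc(Nc2nc3c(=O)[nH]c(C)nc3s2)cc1` gives 20%, and compound 3 `CCOc1nc(C)nc2sc(-c3ccccc3)nc12` gives 11%. On these numbers compound 3 sits between the other two, yet its gap to compound 2 and its gap to compound 1 both fall within the usual scatter, so the three values cannot be told apart. Compound 4 `CCOc1nc(C)nc2sc(-c3ccc(Cl)cc3)nc12` differs from compound 3 by chloro in place of hydrogen on an aromatic carbon, on an aromatic carbon of a six-membered aromatic ring of carbon only, para to a large group. Among the measured compounds shown here, no measured pair shows such a change, so the size of the step is unknown. The step of a number 4 percentage points higher from compound 3 to compound 4 (within the scatter) is expected to stay within the scatter. Compound 4 is therefore estimated at 15%, with a range from 3% to 35%.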

Compound 4, a percentage reported as inhibition, at one concentration (the size of the read-out at that concentration, not a potency): 6%
For compound 4 the middle estimate is 9 percentage points above the measured one; the range from low to high includes it.
By their numbers in this assay, from the lowest: compounds 1, 4, 3 and 2 (each within the scatter of the next, the first and the last beyond it).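

In this assay, among the compounds shown here, chloro in place of hydrogen on an aromatic carbon, para to a large group, gives a first measured step for this change: a number 5 percentage points lower from compound 3 to compound 4 (within the scatter) and so does not tell the two compounds apart. At this position, then, the added chlorine leaves the read-out indistinguishable from that with hydrogen. Nothing on hand accounts for this result.

As far as these compounds go, what an amine, a methoxy group or a carboxylic acid would do on this same aromatic carbon remains open. So does whether any group there could give a step beyond the scatter.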